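The compounds below may be only part of what the source reports. "The series", "measured", "known", "first", "only" and "open" are said of these compounds alone.

Measured so far:
- compound 1 `OC[C@H]1O[C@@H](n2cnc3c(NCc4cccc(Br)c4)ncnc32)[C@H](O)[C@@H]1O`: > 166000 nM
- compound 2 `OC[C@H]1O[C@@H](n2cnc3c(NCc4c(F)ccc(F)c4F)ncnc32)[C@H](O)[C@@H]1O`: "not determined" (no result reported)

In a functional assay on HOS cells (Homo sapiens) for antiproliferative activity, with a stated time of 72 h (on this read-out higher numbers stand for weaker inhibition and lower numbers for stronger inhibition), compound 1 gives > 166000 nM, which is a limit of the assay and not a number. the limit of > 166000 nM in this assay, at which 1 of the 2 values shown sits, is therefore the only position available for the series. For the measured compounds named here, compound 2 has no number, so no measured step exists between compounds.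

Next is compound 3 `OC[C@H]1O[C@@H](n2cnc3c(NCc4cccc(OC(F)(F)F)c4)ncnc32)[C@H](O)[C@@H]1O`, which has trifluoromethoxy in place of bromo on an aromatic carbon, meta to a large group: trifluoromethoxy in place of bromo on an aromatic carbon.

Going by the values given here, the only anchor is compound 1 at its limit of > 166000 nM, so no step beyond the scatter is expected in this assay, and a report of a limit alone is likely. The expected change is a step that the limit leaves unreadable from compound 1 to compound 3. The estimate for compound 3 is 170000 nM, with an expected range from 60000 nM to 350000 nM.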

Compound 3, half-maximal inhibitory concentration: > 166000 nM
Compound 3 gave a limit, no number; the forecaster's own chance of this, stated with the estimate: 80%; the middle value lies beyond the limit too.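

Compound 1 and compound 3 each give only a limit of the assay, not a number, in this assay, so no step can be read between them: the limit of > 166000 nM in this assay, at which 2 of the 3 values shown sit.

The compounds shown leave open whether trifluoromethoxy in place of bromo changes the read-out at all.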